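Hexyloxy series on the shared core: chain extension by one carbon

The source may hold more compounds than are shown below. What is called first, only, known or untested is meant among the compounds shown, and "the series" means these compounds.

Among the measured compounds shown here, compound 2 `CCCCCCOc1cc(-c2ccccc2)c(-c2ccccc2)nn1` is the one compound in this set for which a number, rather than a limit, is known: in an assay on microsomes from liver for inhibition of sterol O-acyltransferase 1 (Rattus norvegicus) (a higher number here means a weaker inhibitor, a lower number a stronger inhibitor), compound 2 gives 72000 nM. Compound 1 `CCCCCC(=O)Nc1cc(-c2ccccc2)c(-c2ccccc2)nn1` sits at a limit of the assay, giving > 300000 nM (the limit of > 300000 nM in this assay, at which 1 of the 2 values shown sits). For the measured compounds named here, the one measured step, an at least 4.1-fold lower number from compound 1 to compound 2 (0.61 log units; beyond the scatter), concerns a different change, hexyloxy in place of (pentylcarbonyl)amino on an aromatic carbon.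

Compound 3 `CCCCCCCOc1cc(-c2ccccc2)c(-c2ccccc2)nn1` differs from compound 2 by methyl in place of hydrogen on a saturated chain carbon, six bonds along the chain from an oxygen on an aromatic ring. Going by the values given here, no measured step in this assay tracks a one-carbon chain extension, so there is no basis for expecting a shift beyond the scatter in either direction. Compound 3 is therefore expected to lie close to compound 2, at an estimated 60000 nM with a range from 25000 nM to 150000 nM, which means an expected step of a 1.2-fold lower number from compound 2 to compound 3 (0.08 log units; within the scatter).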

Compound 3, half-maximal inhibitory concentration: 58000 nM
Compound 3: the middle estimate sits 1.0-fold (0.01 log units) above what was measured; the range from low to high includes it.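

The series now holds a step between two numbers, and in this assay methyl in place of hydrogen on a saturated chain carbon, six bonds along the chain from an oxygen on an aromatic ring, gives a 1.2-fold lower number from compound 2 to compound 3 (0.09 log units; within the scatter). With the heptyloxy chain standing where the amide stood, the result is an at least 5.1-fold lower number from compound 1 to compound 3 (0.71 log units; beyond the scatter), so the second alkoxy chain also reads beyond the scatter against the amide. This step rests on a limit rather than a number for compound 1: the limit of > 300000 nM in this assay, at which 1 of the 3 values shown sits.

From the compounds shown here alone, whether a longer chain such as octyloxy or decyloxy, or a chain ending in an amine or a carboxylic acid, departs from these values remains open. Also open, going by these compounds, is how a hexylamino link on the same aromatic carbon would compare with the hexyloxy link.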